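A few compounds are considered here, and "the series" means these few. Any claim that something is new, unique, unknown or untested is made for them only; others in the source may bear on it.

Compound 1 `Nc1scc(CN2CCN(c3cccc(Cl)c3Cl)CC2)c1C(=O)c1ccc(Cl)cc1` was tested in a functional assay on CHO cells with adenosine receptor A1 (Homo sapiens) as the target, read by cAMP accumulation and immunoassay, with a stated time of 6 min, tested at 0.01 uM (on this read-out higher numbers stand for a weaker effect at the one concentration tested and lower numbers for a stronger effect), and gives 1%, the second highest of the three numbers, with compound 3 nearest and compound 2 furthest. Compound 2 `Nc1scc(CN2CCN(c3cc(Cl)cc(Cl)c3)CC2)c1C(=O)c1ccc(Cl)cc1` gives -1% in this assay, and compound 3 `Nc1scc(CN2CCN(c3ccccc3F)CC2)c1C(=O)c1ccc(Cl)cc1` gives 2.1%. Compound 4 `Nc1scc(CN2CCN(c3ccc(F)c(F)c3)CC2)c1C(=O)c1ccc(Cl)cc1` carries the change (3,4-difluorophenyl in place of 2,3-dichlorophenyl on an amine nitrogen in a ring). Among the measured compounds shown here, the steps that bear on it both replace the group on the amine nitrogen in a ring: a number 2 percentage points lower from compound 1 to compound 2 (within the scatter) and a number 1.1 percentage points higher from compound 1 to compound 3 (within the scatter), and a number 3.1 percentage points higher from compound 2 to compound 3 (within the scatter) is likewise small. All three lie within the scatter, so no step beyond it is expected for compound 4 in this assay. Compound 4 is therefore estimated at 1%, between -9% and 11%, which means an expected step of no change at the digits printed from compound 1 to compound 4 (within the scatter).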

Compound 4, a percentage reported as activity, at one concentration (the size of the read-out at that concentration, not a potency): -3.2%
Beside the measured number, compound 4's estimate is 4.2 percentage points above it; measured number inside the range.
By their numbers in this assay, from the lowest: compounds 4, 2, 1 and 3 (each within the scatter of the next).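

The steps of a number 4.2 percentage points lower from compound 1 to compound 4 (within the scatter) and a number 5.3 percentage points lower from compound 3 to compound 4 (within the scatter) and a number 2.2 percentage points lower from compound 2 to compound 4 (within the scatter) all stay small in this assay when 3,4-difluorophenyl sits on the amine nitrogen in a ring. A phenyl group carrying two fluorine atoms thus joins the dichlorophenyl and 2-fluorophenyl groups at this place, with no separation among the four compounds at this one concentration. Nothing available here accounts for this flat result. Still open, on these data alone, is whether a phenyl group bearing methoxy, a pyridine ring or an alkyl chain on that nitrogen would also leave the read-out unmoved.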